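Fluoro for methoxy on the cinnamamide aryl ring

The source may report more compounds than this note shows. Statements on the series, on what has been measured and on what is new or still open speak of the compounds shown alone.

Compound 3 `COc1ccc(/C=C/C(=O)Nc2cc(C(=O)c3cc(OC)c(OC)c(OC)c3)cc(OC)c2OC)cc1` gives the highest number of the three in a functional assay on ME-180 cells (Homo sapiens) for cytotoxicity, read by MTT assay, with a stated time of 72 h (a lower number here means a stronger inhibitor, a higher number a weaker inhibitor), at 12500 nM. Its nearest neighbour is compound 1 `COc1ccc(/C=C/C(=O)Nc2cc(C(=O)c3cc(OC)c(OC)c(OC)c3)ccc2OC)cc1`, which gives 11800 nM; the two lie within the scatter of each other, as shown by a 1.1-fold higher number from compound 1 to compound 3 (0.03 log units; within the scatter). Among the compounds with values here, compound 2 `COc1ccc(C(=O)c2cc(OC)c(OC)c(OC)c2)cc1NC(=O)/C=C/c1ccc(C(F)(F)F)cc1` gives 800 nM and stands apart from both, the only step beyond the scatter being a 15-fold lower number from compound 1 to compound 2 (1.17 log units; beyond the scatter).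

The unmeasured compound 4 `COc1cc(C(=O)c2cc(OC)c(OC)c(OC)c2)cc(NC(=O)/C=C/c2ccc(F)cc2)c1OC` differs from compound 3 in one place: fluoro in place of methoxy on an aromatic carbon. Within the data shown here, the only measured step at this place is the replacement of methoxy by trifluoromethyl, a 15-fold lower number from compound 1 to compound 2 (1.17 log units; beyond the scatter), which was large and towards a lower number. Here fluoro rather than trifluoromethyl enters, so a step in the same direction but of smaller size is expected in this assay. For compound 4 the expected value in this assay is 4000 nM, with a range from 1500 nM to 10000 nM. This estimate means a step of a 3.1-fold lower number from compound 3 to compound 4 (0.49 log units; beyond the scatter), expected to fall beyond the scatter.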

Compound 4, half-maximal inhibitory concentration: 1000 nM
Estimate against measurement, compound 4: 4.0-fold (0.60 log units) above; measured number below the stated range.
By their numbers in this assay, from the lowest: compounds 2 and 4 (each within the scatter of the next); then compounds 1 and 3 (each within the scatter of the next).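

In this assay the change from 4-methoxyphenyl to 4-fluorophenyl gives a 13-fold lower number from compound 3 to compound 4 (1.10 log units; beyond the scatter) and so counts as a large step in its own right, with a single fluorine atom entering rather than trifluoromethyl. Within the data shown here, until now the only large step at this place was a 15-fold lower number from compound 1 to compound 2 (1.17 log units; beyond the scatter) on the core of compound 1; the drop in number now appears with two different replacements for methoxy and on two cores. Among the listed compounds, nothing at this place goes against that direction.

Still open, as far as these compounds go, is whether the hydrogen, chloro or amino analogues at this place would follow the same direction, and whether fluoro on the core of compound 1 would give a step of similar size. Nothing in hand bears on why the number falls at this place.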